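The source may report more compounds than this note shows. Statements on the series, on what has been measured and on what is new or still open speak of the compounds shown alone.

Working notes on the aryl amide series.

Compound 1 `Cc1ccc(-c2ccnc(C(=O)Nc3ccc(Oc4ccnc5[nH]ccc45)cc3)n2)cc1` in a functional assay on PC-3 cells (Homo sapiens) for cytotoxicity, read by MTT assay, with a stated time of 72 h (a higher number here means a weaker inhibitor, a lower number a stronger inhibitor), gives 6140 nM. Compound 2 `O=C(Nc1ccc(Oc2ccnc3[nH]ccc23)cc1)c1nccc(-c2ccc(Cl)cc2)n1`, which carries chloro in place of methyl on the same phenyl group, is reported in this assay as "not active" (no number reported), without a number. Compound 3 `Cc1ccc(-c2ccnc(C(=O)Nc3ccc(Oc4ccnc5[nH]ccc45)c(F)c3)n2)cc1` gives 520 nM in this assay. Among the compounds with values here, the one measured single-point step runs a 12-fold lower number from compound 1 to compound 3 (1.07 log units; beyond the scatter), and it places compound 3 at the lower of the two numbers so far, with compound 1 standing beyond the scatter above it and compound 2 contributing no number at all.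

Compound 4 `COc1ccc(-c2ccnc(C(=O)Nc3ccc(Oc4ccnc5[nH]ccc45)c(F)c3)n2)cc1` is the next entry. Relative to compound 3 the change is methoxy in place of methyl on an aromatic carbon. Within the data shown here, no measured step touches this position: the only step recorded, from compound 1 to compound 3, concerns the fluoro on the anilide ring and says nothing about the substituent on the pendant phenyl group. Compound 2 differs from compound 1 at the relevant position, but it is reported without a number, so no size can be drawn from that pair either. With nothing to anchor a direction, the step of a 1.3-fold higher number from compound 3 to compound 4 (0.10 log units; within the scatter) is expected to stay within the scatter, and the range is kept wide to reflect that. For compound 4 the expected value in this assay is 650 nM, with a range from 150 nM to 3000 nM.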

Compound 4, half-maximal inhibitory concentration: 14100 nM
For compound 4 the middle estimate is 22-fold (1.34 log units) below the measured one; the measured number lies above the stated range.
By their numbers in this assay, from the lowest: compound 3; then compound 1; then compound 4.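

The change from 4-methylphenyl to 4-methoxyphenyl runs a 27-fold higher number from compound 3 to compound 4 (1.43 log units; beyond the scatter) in this assay and gives the first measured size at this position, on an aromatic carbon para to a large group. Within the data shown here, until now, the only other change here was chloro in place of methyl from compound 1 to compound 2, and with "not active" reported for compound 2 that pair had no number to give a size or direction. Among the groups with a number at this position, on a background that keeps the fluoro of compound 3, methyl now stands with the lower number and methoxy with the higher, so this position is far from indifferent to the choice of substituent, and nothing available explains the size of this step.

Among these compounds, whether the oxygen of the methoxy or simply any replacement of methyl accounts for the step remains open, since only one such pair has a number on each side. A hydroxy group, an amino group, a longer chain such as ethoxy, or chloro on the fluoro-bearing background would show how far this sensitivity extends, and whether the step holds without the fluoro is also unsettled.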